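This account rests on a few compounds, and the source may have more. Where it says the series, first, only, none or still open, it means among the compounds named here.

Compound 1 `N=C(NCCCc1c[nH]cn1)NCCC(c1ccccc1)c1ccccn1` gives 97.7 nM in a functional assay on ileum for antagonist activity at histamine H1 receptor (Cavia porcellus); a higher number here means weaker binding, a lower number tighter binding. Among the three numbers measured it stands second highest; nearest is compound 3 `N=C(NCCCc1c[nH]cn1)NCCC(c1ccc(C(F)(F)F)cc1)c1ccccn1` with 282 nM, furthest is compound 2 `N=C(NCCCc1c[nH]cn1)NCCC(c1ccc(F)cc1)c1ccccn1` with 22.4 nM. Compound 4 `N=C(NCCCc1c[nH]cn1)NCCC(c1ccccn1)c1ccccn1` differs from compound 1 in one place: pyridin-2-yl in place of phenyl on a saturated chain carbon bound to an aromatic carbon and a saturated chain carbon. For the measured compounds named here, no measured step swaps the phenyl for another ring, so the closest guides are a 4.4-fold lower number from compound 1 to compound 2 (0.64 log units; beyond the scatter) and a 2.9-fold higher number from compound 1 to compound 3 (0.46 log units; beyond the scatter), both modest and in opposite directions, showing that changes at this ring move the number only moderately. A modest step at most is therefore expected in this assay for compound 4, with no firm direction. Compound 4 is estimated at 80 nM, within 30 nM to 250 nM, which means an expected step of a 1.2-fold lower number from compound 1 to compound 4 (0.09 log units; within the scatter).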

Compound 4, dissociation constant: 389 nM
Compound 4: the middle estimate sits 4.9-fold (0.69 log units) below what was measured; the whole stated range lies below it.
By their numbers in this assay, from the lowest: compound 2; then compound 1; then compounds 3 and 4 (each within the scatter of the next).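

Replacing the phenyl ring itself, rather than adding to it, also moves the number in this assay: a 4.0-fold higher number from compound 1 to compound 4 (0.60 log units; beyond the scatter), so a swap that keeps the heavy-atom count and adds one hydrogen-bond acceptor still registers at this position. The pyridin-2-yl and 4-(trifluoromethyl)phenyl rings land together, a 1.4-fold higher number from compound 3 to compound 4 (0.14 log units; within the scatter), while the 4-fluorophenyl ring stands well apart, a 17-fold higher number from compound 2 to compound 4 (1.24 log units; beyond the scatter). Nothing available accounts for these shifts. From the compounds shown here alone, whether a pyridin-3-yl, 4-chlorophenyl or 4-methoxyphenyl ring on this carbon would fall nearer the 4-fluorophenyl result or the other two stays open.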